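Acetyl for Cyano on Two Related Cores

The compounds below may be only part of what the source reports. "The series", "measured", "known", "first", "only" and "open" are said of these compounds alone.

Compound 1, `CCCCN(CC)c1cc(C)nc2c1NC(=O)CN2c1ccc(C#N)cc1C`, in an assay on frontal cortex for displacement of a labelled ligand from corticotropin-releasing factor receptor 1 (Rattus norvegicus) (on this read-out higher numbers stand for weaker inhibition and lower numbers for stronger inhibition), gives 3.3 nM.
Compound 2, `CCCCN(CC)c1nc(C)nc2c1NC(=O)CN2c1ccc(C#N)cc1C`, in this assay gives 573 nM.
Compound 3, `CCCCN(CC)c1cc(C)nc2c1NC(=O)CN2c1ccc(C(C)=O)cc1C`, in this assay gives 5.8 nM.

Compound 3 differs from compound 1 by acetyl in place of cyano on an aromatic carbon, and the resulting step is a 1.8-fold higher number from compound 1 to compound 3 (0.24 log units; within the scatter). Compound 2 rests on a different core from compound 1; the difference between the two cores is not broken down here. Its value in this assay stands far higher than the values of both compound 1 and compound 3, beyond the scatter in each case.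

Compound 4, `CCCCN(CC)c1nc(C)nc2c1NC(=O)CN2c1ccc(C(C)=O)cc1C`, has not yet been measured. It differs from compound 2 by acetyl in place of cyano on an aromatic carbon, the same change that leads from compound 1 to compound 3. The step from compound 2 to compound 4 in this assay is expected to be a 1.7-fold higher number from compound 2 to compound 4 (0.24 log units; within the scatter), an estimate that rests on the measured step of a 1.8-fold higher number from compound 1 to compound 3 (0.24 log units; within the scatter), which lay within the scatter. Compound 4 is therefore estimated at 1000 nM, with a range from 300 nM to 3500 nM.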

Compound 4, half-maximal inhibitory concentration: 713 nM
Beside the measured number, compound 4's estimate is 1.4-fold (0.15 log units) above it; low and high end bracket the measured number.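

In this assay, putting acetyl in place of cyano on an aromatic carbon gives a 1.2-fold higher number from compound 2 to compound 4 (0.09 log units; within the scatter), so on this core too the step stays within the scatter. The steps on the two cores agree: the same change on two cores in this assay, a 1.8-fold higher number (0.24 log units; within the scatter) from compound 1 to compound 3 and a 1.2-fold higher number (0.09 log units; within the scatter) from compound 2 to compound 4, 1.4-fold (0.15 log units) apart, within the scatter of two such steps. This shows that this one change carried across this one pair of cores within the scatter; it does not show that it would carry to any other core, and it does not account for the large gap between the values on the two cores.

The compounds shown leave open whether a carboxylic acid or an amine in place of cyano would also give matching steps on both cores. Among these compounds, with only one change followed across the two cores, how widely such agreement holds also remains open.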